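Switching the aryl group on the enone of compound 3

This account rests on a few compounds, and the source may have more. Where it says the series, first, only, none or still open, it means among the compounds named here.

Measured compounds:
compound 1 `COc1cccc(/C=C/C(=O)c2cc3ccc(O)cc3oc2=O)c1OC`: 7000 nM
compound 2 `COc1cccc(COc2ccc3cc(C(=O)/C=C/c4ccc(Cl)cc4Cl)c(=O)oc3c2)c1`: "not determined" (no result reported)
compound 3 `COc1cccc(COc2ccc3cc(C(=O)/C=C/c4c(Cl)cccc4Cl)c(=O)oc3c2)c1`: 12500 nM

Of the compounds shown here, three have been tested in a functional assay on MOLT-4 cells (Homo sapiens) for cytotoxicity, read by MTT assay, with a stated time of 72 h; a higher number here means a weaker inhibitor, a lower number a stronger inhibitor. Compound 1 gives 7000 nM in this assay, and compound 3 gives 12500 nM, the highest number of the two, although the gap to compound 1 lies within the scatter. For compound 2 this assay reports "not determined" (no result reported), so no number is available for it. Compound 1 and compound 3 differ in more than one place, so their values are simply set side by side.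

Compound 4 `COc1cccc(COc2ccc3cc(C(=O)/C=C/c4cccc(OC)c4OC)c(=O)oc3c2)c1` has not been measured. It differs from compound 3 by 2,3-dimethoxyphenyl in place of 2,6-dichlorophenyl on a double-bonded chain carbon bound to a double-bonded chain carbon. Within the data shown here, compound 1 carries the same 2,3-dimethoxyphenyl group on its enone but on a different core, so no single measured step isolates this change. Since compound 1 gives 7000 nM and compound 3 gives 12500 nM, no step beyond the scatter is expected from compound 3 to compound 4, a 1.3-fold lower number from compound 3 to compound 4 (0.10 log units; within the scatter). Compound 4 is therefore estimated at 10000 nM in this assay, within a range of 3000 nM to 35000 nM.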

Compound 4, half-maximal inhibitory concentration: 22800 nM
For compound 4 the middle estimate is 2.3-fold (0.36 log units) below the measured one; the measured number falls inside the stated range.
By their numbers in this assay, from the lowest: compounds 1, 3 and 4 (each within the scatter of the next, the first and the last beyond it).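

With the 3-methoxybenzyl group on the oxygen, putting 2,3-dimethoxyphenyl in place of 2,6-dichlorophenyl on a double-bonded chain carbon bound to a double-bonded chain carbon gives a 1.8-fold higher number from compound 3 to compound 4 (0.26 log units; within the scatter) in this assay, so this aryl change is not resolved from the scatter. With 2,3-dimethoxyphenyl held constant, 3-methoxybenzyl in place of hydrogen on an oxygen on an aromatic ring gives a 3.3-fold higher number from compound 1 to compound 4 (0.51 log units; beyond the scatter), a modest step and the only one of the two printed as beyond the scatter. No measurement shown here accounts for either step.

The compounds shown do not tell whether the step at the oxygen would hold with 2,6-dichlorophenyl on the enone. They also leave open how an amine, a carboxylic acid or a longer chain on that oxygen would read in this assay in place of 3-methoxybenzyl.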